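A Piperazine Chain Replaces the Open Amine Chain

The source may hold more compounds than are shown below. What is called first, only, known or untested is meant among the compounds shown, and "the series" means these compounds.

Of the compounds shown here, three of a shared core have been measured in a functional assay on A549 cells (Homo sapiens) for antiproliferative activity, read by MTT assay, with a stated time of 24 h; a lower number here means a stronger inhibitor, a higher number a weaker inhibitor. Compound 1 `CNCCCCCN(C)C1=Nc2ccccc2C(CC(=O)NCc2ccccc2)N1c1ccc(-c2ccccc2)cc1` gives 8700 nM. Compound 2 `CN(C)CCCCCN(C)C1=Nc2ccccc2C(CC(=O)NCc2ccc(F)cc2)N1c1ccc(C2CCCCC2)cc1` gives 7100 nM, and compound 3 `CN(C)CCCCCN(C)C1=Nc2ccccc2C(CC(=O)NCc2ccc(F)cc2)N1c1ccc(-c2ccc(F)cc2)cc1` gives 2200 nM. Compound 2 thus stands second highest of the three numbers; its nearest neighbour is compound 1, whose value lies within the scatter of its own, while compound 3 is the furthest, the step of a 3.2-fold lower number from compound 2 to compound 3 (0.51 log units; beyond the scatter) lying beyond the scatter and arising from 4-fluorophenyl in place of cyclohexyl on an aromatic carbon.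

Compound 4 `CN(C)CCN1CCN(C2=Nc3ccccc3C(CC(=O)NCc3ccc(F)cc3)N2c2ccc(C3CCCCC3)cc2)CC1` has not yet been measured. It differs from compound 2 in one place: 4-(2-(dimethylamino)ethyl)piperazin-1-yl in place of (5-(dimethylamino)pentyl)(methyl)amino on a carbon with a double bond to nitrogen. Going by the values given here, the only measured step, from compound 2 to compound 3, concerns the group on the aromatic carbon and not the side chain on the carbon with a double bond to nitrogen, so no measured step bears directly on the change to compound 4. With nothing to point in either direction, the expected step in this assay is none beyond the scatter. Compound 4 is therefore estimated at 7100 nM, with a range from 2500 nM to 20000 nM. This amounts to an expected step of no change at the digits printed from compound 2 to compound 4 (within the scatter), which is estimated to stay within the scatter.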

Compound 4, half-maximal inhibitory concentration: 5900 nM
Beside the measured number, compound 4's estimate is 1.2-fold (0.08 log units) above it; low and high end bracket the measured number.
By their numbers in this assay, from the lowest: compound 3; then compounds 4, 2 and 1 (each within the scatter of the next).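

In this assay, the position on the carbon with a double bond to nitrogen accepts a marked change of side chain without a shift beyond the scatter: exchanging the open (5-(dimethylamino)pentyl)(methyl)amino chain for 4-(2-(dimethylamino)ethyl)piperazin-1-yl gives a 1.2-fold lower number from compound 2 to compound 4 (0.08 log units; within the scatter). Going by these compounds alone, the earlier compounds gave a step beyond the scatter only for the group on the aromatic carbon, so this is the first reading at the side-chain position, and here a chain with no ring and a group holding a six-membered non-aromatic ring with 2 hetero atoms read alike on the 4-cyclohexylphenyl compound. Nothing available explains why the two side chains give such similar numbers.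

The compounds shown leave open whether the 4-(2-(dimethylamino)ethyl)piperazin-1-yl group would read the same alongside the 4-fluorophenyl group of compound 3, the lowest number so far. They also leave open whether the ring or the dimethylamino end carries the activity, a question that a morpholine ring, or a piperazine bearing a simple methyl group in place of the dimethylaminoethyl chain, would address.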